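The compounds below may be only part of what the source reports. "The series", "measured", "known", "first", "only" and "open" are said of these compounds alone.

Compound 1 `C=C(CC)C(=O)c1ccc(OCC(=O)NCCO)c(Cl)c1Cl` carries a 2-hydroxyethyl group on the amide-type nitrogen of a glycolamide side chain attached to the shared core. In a functional assay on CLL cells (Homo sapiens) for cytotoxicity, read by MTT assay, with a stated time of 48 h (on this read-out lower numbers stand for an effect already at smaller amounts and higher numbers for an effect only at larger amounts of compound), compound 1 gives only a limit of the assay, > 25000 nM. Compound 3 `C=C(CC)C(=O)c1ccc(OCC(=O)NCC(=O)O)c(Cl)c1Cl` likewise reaches only a limit in this assay, > 25000 nM. Compound 2 `C=C(CC)C(=O)c1ccc(OCC(=O)Nc2ccc(C(N)=O)cc2)c(Cl)c1Cl`, which bears a 4-carbamoylphenyl group on the same nitrogen, gives a measured number in this assay of 3700 nM. Among the measured compounds shown here, the one readable step among the three is an at least 6.7-fold lower number from compound 1 to compound 2 (0.82 log units; beyond the scatter); the step of an at least 6.7-fold higher number from compound 2 to compound 3 (0.82 log units; beyond the scatter) points the same way, whereas the step that the two limits leave unreadable from compound 1 to compound 3. Two of the three values therefore sit at the limit of > 25000 nM in this assay, at which 2 of the 3 values shown sit, so compound 1 stands only as a limit, not as a number.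

Compound 4 `C=C(CC)C(=O)c1ccc(OCC(=O)Nc2ccc(O)c(Cl)c2)c(Cl)c1Cl` differs from compound 1 by 3-chloro-4-hydroxyphenyl in place of 2-hydroxyethyl on an amide-type nitrogen. For the measured compounds named here, this change resembles the one from compound 1 to compound 2, where a substituted phenyl group on the amide-type nitrogen likewise replaces 2-hydroxyethyl. Compound 4 is therefore expected to show a step of an at least 5.5-fold lower number from compound 1 to compound 4 (0.74 log units; beyond the scatter), away from the limit and beyond the scatter. Compound 4 is estimated to give 4500 nM in this assay, with a range from 1500 nM to 15000 nM.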

Compound 4, half-maximal effective concentration: 5500 nM
For compound 4 the middle estimate is 1.2-fold (0.09 log units) below the measured one; the range from low to high includes it.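

In this assay, among the compounds shown here, 3-chloro-4-hydroxyphenyl on the amide-type nitrogen gives an at least 4.5-fold lower number from compound 1 to compound 4 (0.65 log units; beyond the scatter), and the same group in place of carboxymethyl gives an at least 4.5-fold lower number from compound 3 to compound 4 (0.65 log units; beyond the scatter), so compound 2 is no longer the only compound here with a measured number rather than a limit. The two substituted phenyl groups do not separate, with a 1.5-fold higher number from compound 2 to compound 4 (0.17 log units; within the scatter), so exchanging 4-carbamoylphenyl for 3-chloro-4-hydroxyphenyl at this place has no readable effect, even though the two groups share no substituent. Among these four compounds, both with a substituted phenyl group on this nitrogen give numbers and no compound goes against that, while compound 1 and compound 3, with their saturated chains, remain at the assay limit: the limit of > 25000 nM in this assay, at which 2 of the 4 values shown sit.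

As far as these compounds go, what an unsubstituted phenyl group or a longer saturated chain such as hexyl would give on this nitrogen remains open, and with it whether the aromatic ring or its substituents matter for the step. Also open, from the compounds shown here alone, is how the chlorine and the hydroxyl of compound 4 count separately, which a 4-hydroxyphenyl or a 3-chlorophenyl group on the same nitrogen would address.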